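Replacing a Propyl Chain with a Nitrophenyl Ring

The compounds below may be only part of what the source reports. "The series", "measured", "known", "first", "only" and "open" are said of these compounds alone.

Compound 1 `CCCC(=O)Nc1cccc(NC(=O)COc2ccc3c(=O)ccoc3c2)c1` carries a propyl group on one of its two amide carbonyls. Within the data shown here, in an assay on isolated protein for inhibition of Rho-associated protein kinase 2 (Homo sapiens), read by scintillation counting, radiometric assay and 33P incorporation, with a stated time of 40 min, in the presence of a further agent that is not named here (on this read-out higher numbers stand for weaker inhibition and lower numbers for stronger inhibition), compound 1 gives 176 nM, the highest of the three numbers measured so far, which makes it the weakest inhibitor among them. Two close relatives replace that propyl group with an aromatic ring. Compound 2 `COc1ccc(C(=O)Nc2cccc(NC(=O)COc3ccc4c(=O)ccoc4c3)c2)cc1` gives 7 nM, and compound 3 `O=C(COc1ccc2c(=O)ccoc2c1)Nc1cccc(NC(=O)c2ccc([N+](=O)[O-])cc2)c1` gives 15 nM. Both steps are large: a 25-fold lower number from compound 1 to compound 2 (1.40 log units; beyond the scatter) and a 12-fold lower number from compound 1 to compound 3 (1.07 log units; beyond the scatter). Between the two aromatic variants the gap is smaller, a 2.1-fold higher number from compound 2 to compound 3 (0.33 log units; beyond the scatter).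

Compound 4 `O=C(COc1ccc2c(=O)ccoc2c1)Nc1cccc(NC(=O)c2cccc([N+](=O)[O-])c2)c1` has not yet been measured. It differs from compound 1 by a single change: 3-nitrophenyl in place of propyl on a carbonyl carbon. This change is of the same kind as the two measured steps from compound 1, in which a propyl group gives way to a substituted phenyl ring on the same carbonyl carbon, and both of those steps lowered the number well beyond the scatter. Among the measured compounds shown here, compound 3 carries 4-nitrophenyl and gave 15 nM, whereas compound 4 carries 3-nitrophenyl, and no measured pair shows what that exchange alone does. A large downward step is therefore expected for compound 4, an 8.8-fold lower number from compound 1 to compound 4 (0.94 log units; beyond the scatter), with a wide range around it. Compound 4 is estimated at 20 nM, between 6 nM and 70 nM.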

Compound 4, half-maximal inhibitory concentration: 41 nM
Compound 4: the middle estimate sits 2.1-fold (0.31 log units) below what was measured; the range from low to high includes it.
By their numbers in this assay, from the lowest: compound 2; then compound 3; then compound 4; then compound 1.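

In this assay a ring on this carbonyl carbon still helps when the nitro group changes place: the swap of propyl for 3-nitrophenyl gives a 4.3-fold lower number from compound 1 to compound 4 (0.63 log units; beyond the scatter), so all three ring-bearing compounds shown read lower than compound 1, though this gain is the smallest of the three. Among these compounds, what is new is that the placement of the group on the ring matters, since exchanging 4-nitrophenyl for 3-nitrophenyl gives a 2.7-fold higher number from compound 3 to compound 4 (0.44 log units; beyond the scatter), the first measured pair to isolate that exchange, and the distance from the 4-methoxyphenyl ring grows to a 5.9-fold higher number from compound 2 to compound 4 (0.77 log units; beyond the scatter). Nothing measured here explains why the two nitrophenyl rings differ.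

The compounds shown leave open whether moving the methoxy group of compound 2 in the same way would raise the number as moving the nitro group did, so this shift may or may not be particular to nitro. They also leave open how an amine or a carboxylic acid on the ring would behave, and whether a longer chain would do better than propyl on this carbonyl carbon.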